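(Ethylsulfonyl)amino replaces 1,3-thiazol-2-yl on the fused core

The source may hold more compounds than are shown below. What is called first, only, known or untested is meant among the compounds shown, and "the series" means these compounds.

compound 1 `COc1c(Cl)ccc2c1CCC2c1ncc[nH]1` — 451 nM
compound 2 `c1cc(-c2nccs2)c2c(c1)C(c1ncc[nH]1)CC2` — 426 nM
compound 3 `Cc1ccc2c(c1NS(C)(=O)=O)CCC2c1ncc[nH]1` — 33 nM

All three have been read in a functional assay on CHO cells for agonist activity at Alpha-1A adrenergic receptor (Homo sapiens), read by FLIPR and calcium flux; a higher number here means that more compound is needed for the effect, a lower number that less compound is needed. Compound 2 gives 426 nM, the second highest of the three numbers. Compound 1 at 451 nM lies within the scatter of compound 2, so the two cannot be told apart. Compound 3 at 33 nM sits far beyond the scatter from compound 2, and this is the only clear separation in the measured set.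

Compound 4 `CCS(=O)(=O)Nc1cccc2c1CCC2c1ncc[nH]1` has not yet been measured. It differs from compound 2 in a single place: (ethylsulfonyl)amino in place of 1,3-thiazol-2-yl on an aromatic carbon. For the measured compounds named here, no pair of measured compounds differs in exactly one place, so there is no measured step that maps onto this change directly. Going by the values given here, the only anchor is compound 3, which gives 33 nM and is the member of the set whose make-up lies closest to compound 4. On that ground a 6.1-fold lower number from compound 2 to compound 4 (0.78 log units; beyond the scatter) toward a lower number is expected, a step beyond the scatter. Compound 4 is expected to give 70 nM, with a range of 20 nM to 250 nM. Whether the thiazole substituent and the sulfonyl-bearing substituent behave alike on this core cannot be said from three compounds alone.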

Compound 4, half-maximal effective concentration: 32 nM
Estimate against measurement, compound 4: 2.2-fold (0.34 log units) above, and the stated range covers the measured number.
By their numbers in this assay, from the lowest: compounds 4 and 3 (each within the scatter of the next); then compounds 2 and 1 (each within the scatter of the next).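

In this assay, for the compounds shown here, the exchange of 1,3-thiazol-2-yl for (ethylsulfonyl)amino gives a 13-fold lower number from compound 2 to compound 4 (1.12 log units; beyond the scatter), the first step that can be read at a single place, and it is large. The earlier compounds shown here differ from each other in more than one place, so they could not show that this aromatic carbon, ortho to a fused ring and meta to a fused ring, matters on its own: with the rest of the structure held constant, the group here clearly moves the number. The change replaces a five-membered aromatic ring with a ring-free group carrying a hydrogen-bond donor, but no measurement at hand explains the step.

Going by these compounds alone, the single step cannot separate the loss of the ring from the arrival of the sulfonyl group or of the amino hydrogen. An acetylamino group or a plain amine at the same carbon, or a propyl or longer chain in place of the ethyl on the sulfonyl, would show which part of the (ethylsulfonyl)amino group the number follows.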